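The source may report more compounds than this note shows. Statements on the series, on what has been measured and on what is new or still open speak of the compounds shown alone.

Compound 1 `Cn1cnnc1SCCc1nnc(SCC(=O)Nc2ccc([N+](=O)[O-])cc2)o1`: in an ADME assay on NIH3T3 cells (Mus musculus) for cytotoxicity, read by MTT assay, with a stated time of 24 h (on this read-out higher numbers stand for weaker inhibition and lower numbers for stronger inhibition), compound 1 gives > 500 ug/mL, which is a limit of the assay and not a number.
Compound 2 `Cn1cnnc1SCCc1nnc(SCC(=O)Nc2nc3ccc(F)cc3s2)o1`: in this assay compound 2 gives > 500 ug/mL, likewise a limit and not a number.
Compound 3 `Cn1cnnc1SCCc1nnc(SCC(=O)Nc2ccc(Cl)cc2)o1`: in this assay compound 3 gives > 500 ug/mL, again a limit rather than a number.

Among the measured compounds shown here, compound 2 therefore stands at the same limit as every other value shown, as the limit of > 500 ug/mL in this assay, at which 3 of the 3 values shown sit, records; no compound in this set yields a measured number. The unmeasured compound 4 `Cn1cnnc1SCCc1nnc(SCC(=O)Nc2nc3ccc(Cl)cc3s2)o1` differs from compound 2 in one place: chloro in place of fluoro on an aromatic carbon.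

For the measured compounds named here, the only measured step, a step that the two limits leave unreadable from compound 1 to compound 3, runs between two limits and its size cannot be read, and it concerns a different exchange on a different ring than the one here. Going by the values given here, no measured step bears directly on the change from compound 2 to compound 4. What the data support is the flat picture given by the limit of > 500 ug/mL in this assay, at which 3 of the 3 values shown sit: three structural variations across the shared core all leave the read-out at the limit. On this basis compound 4 is expected to behave as compound 2 does, with a step of a number no higher from compound 2 to compound 4 (the limit leaves the size open) that is no step beyond the scatter and most likely another limit. Compound 4 is thus estimated at 500 ug/mL, with a range from 250 ug/mL to 1000 ug/mL.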

Compound 4, half-maximal inhibitory concentration: 422 ug/mL
For compound 4 the middle estimate is 1.2-fold (0.07 log units) above the measured one; low and high end bracket the measured number.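

With chloro in place of fluoro on an aromatic carbon of the fused system of two rings, a measured number appears for the only time in this set: in this assay compound 4 gives 422 ug/mL. The exchange gives an at least 1.1-fold lower number from compound 2 to compound 4 (0.07 log units; that floor lies within the scatter), and as only this floor is known, the change at this position cannot be called larger than the scatter, though its true size may be. Compound 4 thus stands as the only compound with a measured number, and the other three remain limits rather than numbers: the limit of > 500 ug/mL in this assay, at which 3 of the 4 values shown sit.

The compounds shown leave open how far compound 2 really lies from compound 4, and the step from compound 1 to compound 3, running between two limits, cannot be read, so nothing shows whether chloro has a similar result on the other aromatic ring. They also leave open what a bromo group, a methoxy group or an amine on this same aromatic carbon would do to the read-out.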